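Expected Effect of a Large Aromatic Arm on Compound 1

The source may report more compounds than this note shows. Statements on the series, on what has been measured and on what is new or still open speak of the compounds shown alone.

Compound 1 `O=C(CSC(=S)N[C@H]1CCOC1=O)Nc1ccccc1`: > 128000 nM
Compound 2 `O=C(CSC(=S)N[C@H]1CCOC1=O)Nc1ccc(Cl)cc1Cl`: 29200 nM
Compound 3 `O=C(CSC(=S)N[C@H]1CCOC1=O)Nc1cccc([N+](=O)[O-])c1`: 5460 nM

In a functional assay on MCF7 cells (Homo sapiens) for cytotoxicity, read by MTT assay, with a stated time of 72 h (a higher number here means a weaker inhibitor, a lower number a stronger inhibitor), compound 1 gives > 128000 nM, which is the limit of > 128000 nM in this assay, at which 1 of the 3 values shown sits, a limit of the assay rather than a number. Compound 2 gives 29200 nM in this assay. Compound 3 gives 5460 nM. Within the data shown here, the one single-point change with data, an at least 23-fold lower number from compound 1 to compound 3 (1.37 log units; beyond the scatter), shows that adding a group to the aromatic ring of compound 1 can move the number far down.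

Compound 4 `O=C(CSC(=S)N[C@H]1CCOC1=O)Nc1ccc(C(=O)/C=C/c2ccccc2)cc1` differs from compound 1 by (2-phenylethenyl)carbonyl in place of hydrogen on an aromatic carbon. The group entering is much larger than nitro, so the step measured for compound 3 is only a rough guide, but it points downward. Compound 4 is therefore expected near 10000 nM, within 2000 nM to 60000 nM. The expected step is an at least 12-fold lower number from compound 1 to compound 4 (1.10 log units; beyond the scatter).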

Compound 4, half-maximal inhibitory concentration: 44300 nM
Compound 4: middle estimate off by 4.4-fold (0.65 log units), on the low side; the measured number falls inside the stated range.
By their numbers in this assay, from the lowest: compound 3; then compounds 2 and 4 (each within the scatter of the next). At a limit, above all of these: compound 1.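

Placing (2-phenylethenyl)carbonyl on an aromatic carbon, para to a large group, gives an at least 2.8-fold lower number from compound 1 to compound 4 (0.46 log units; beyond the scatter) and so shows that a group this large at this place still brings the number down from the limit. The true size of this step cannot be read, because compound 1 has a limit and not a number: the limit of > 128000 nM in this assay, at which 1 of the 4 values shown sits.

An acetyl group or an amine at this same place would help show which part of the entering group carries the step.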